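The source may report more compounds than this note shows. Statements on the series, on what has been measured and on what is new or still open speak of the compounds shown alone.

Three compounds have been measured in an ADME assay on L132 cells (Homo sapiens) for cytotoxicity, read by MTT assay, with a stated time of 72 h; a lower number here means a stronger inhibitor, a higher number a weaker inhibitor:

compound 1, `COc1ccc(C2=C(c3cc(OC)c(OC)c(OC)c3)C(=O)C(OC(C)=O)C2)cc1Cl`, gives < 1 ug/mL;
compound 2, `COc1ccc(C2=C(c3cc(OC)c(OC)c(OC)c3)C(=O)C(O)C2)cc1NC(=O)c1ccccc1`, gives > 100 ug/mL;
compound 3, `COc1ccc(C2=C(c3cc(OC)c(OC)c(OC)c3)C(=O)C(O)C2)cc1`, gives < 1 ug/mL.

The value of compound 1 is a limit of this assay and not a number. The value of compound 2 is likewise a limit. The value of compound 3 is a limit as well, so compound 3 stands at the limit of < 1 ug/mL in this assay, at which 2 of the 3 values shown sit, while compound 2 stands alone at the limit of > 100 ug/mL in this assay, at which 1 of the 3 values shown sits. Going by the values given here, the one measured step between single-point neighbours is an at least 100-fold lower number from compound 2 to compound 3 (2.00 log units; beyond the scatter), a large move down to the lower limit.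

Compound 4, `COc1ccc(C2=C(c3cc(OC)c(OC)c(OC)c3)C(=O)C(O)C2)cc1Cl`, has not yet been measured. It differs from compound 3 in one place: chloro in place of hydrogen on an aromatic carbon. The measured step from compound 2 to compound 3 concerns a different group on the same ring and runs toward the limit at which compound 3 already sits, so it offers no reason to expect a rise. Compound 1, which carries the same chloro group together with a further change elsewhere on the core, also sits at the limit of < 1 ug/mL in this assay, at which 2 of the 3 values shown sit. Compound 4 is therefore expected to remain at that limit, with a step that the limit leaves unreadable from compound 3 to compound 4 as the expected step, none beyond the scatter. The estimate for compound 4 in this assay is 0.5 ug/mL, in the range 0.1 ug/mL to 2 ug/mL.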

Compound 4, half-maximal inhibitory concentration: < 1 ug/mL
Compound 4: no number, only a limit (the forecaster's own chance of this, stated with the estimate: 75%); the middle value does not contradict the limit.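

In this assay compound 4 gives < 1 ug/mL, which is a limit of the assay and not a number. Replacing benzamido on the 4-methoxyphenyl ring with chloro gives an at least 100-fold lower number from compound 2 to compound 4 (2.00 log units; beyond the scatter), so this position now has two replacements for benzamido, hydrogen and chloro, that both end at the low limit, and compound 2 remains the only compound apart from them: the limit of > 100 ug/mL in this assay, at which 1 of the 4 values shown sits. The steps from compound 3 to compound 4 and from compound 1 to compound 4 cannot be read, and the data therefore do not tell whether chloro in place of hydrogen, or hydrogen in place of acetyl on the oxygen, changes the number at all: the limit of < 1 ug/mL in this assay, at which 3 of the 4 values shown sit.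

The compounds shown leave open how far the three compounds at the low limit lie from one another, and a real difference among them would need a measurement that gives a number rather than a limit. Also open, as far as these compounds go, is where an amine or a carboxylic acid at this place on the ring would fall, whether with chloro and hydrogen or with benzamido.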